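Ester chain and thiophene position in a dihydropyrimidinone series

This account rests on a few compounds, and the source may have more. Where it says the series, first, only, none or still open, it means among the compounds named here.

Measured compounds in an assay on membranes from CHO cells for displacement of a labelled ligand from adenosine receptor A1 (Homo sapiens), read by scintillation counting, with a stated time of 60 min, tested at 1 uM; a higher number here means more inhibition at the concentration tested (going by the name of the read-out), a lower number less inhibition:
compound 1, `CCOC(=O)C1=C(C)N(C)C(=O)NC1c1cccs1`, gives 1%;
compound 2, `CCCOC(=O)C1=C(C)N(C)C(=O)NC1c1cccs1`, gives 9%;
compound 3, `CCCOC(=O)C1=C(C)N(C)C(=O)NC1c1ccsc1`, gives 2%.

The change methyl in place of hydrogen on a saturated chain carbon, two bonds along the chain from an oxygen next to a carbonyl group gives a number 8 percentage points higher from compound 1 to compound 2 (within the scatter). From compound 2 to compound 3 the read-out moves by a number 7 percentage points lower from compound 2 to compound 3 (within the scatter). The difference between the cores of compound 1 and compound 3 is not broken down here.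

Compound 4, `CC1=C(C(=O)OCC(C)C)C(c2ccsc2)NC(=O)N1C`, is not yet measured in this assay. It arises from compound 3 by methyl in place of hydrogen on a saturated chain carbon bound to two saturated chain carbons, the same kind of change as from compound 1 to compound 2, though the place differs: there the carbon sat two bonds along the chain from an oxygen next to a carbonyl group, here it is bound to two saturated chain carbons. Because a number 8 percentage points higher from compound 1 to compound 2 (within the scatter) stayed within the scatter, the expected step is a number 3 percentage points higher from compound 3 to compound 4 (within the scatter). Compound 4 is thus estimated at 5%, between -6% and 16%.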

Compound 4, a percentage reported as inhibition, at one concentration (the size of the read-out at that concentration, not a potency): 8%
Beside the measured number, compound 4's estimate is 3 percentage points below it, within the range that was stated.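

In this assay, methyl in place of hydrogen on a saturated chain carbon bound to two saturated chain carbons gives a number 6 percentage points higher from compound 3 to compound 4 (within the scatter), and the change reads alike on the two cores: the same change on two cores in this assay, a number 8 percentage points higher (within the scatter) from compound 1 to compound 2 and a number 6 percentage points higher (within the scatter) from compound 3 to compound 4, 2 percentage points apart, within the scatter of two such steps

This agreement is only between two steps that each stay within the scatter, and it does not show that the methyl has a real effect on either core. The methyl also sits at a different place in the two pairs, and a single tested concentration gives no potency, leaving transfer to a core with a larger read-out untested.

Still open, on these data alone, is whether a longer chain on the ester, or a carboxylic acid in place of the ester, would move the read-out beyond the scatter.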